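The source may report more compounds than this note shows. Statements on the series, on what has been measured and on what is new or still open speak of the compounds shown alone.

Compound 2 `CC(C)(C)NC(=O)N1CCC[C@H]1C(=O)N1CCC(NS(=O)(=O)c2cc(S(=O)(=O)c3ccccc3)ccc2C(F)(F)F)CC1` carries a (tert-butyl)carbamoyl group on the nitrogen of the pyrrolidine of the shared core. In a functional assay on U2OS cells for antagonist activity at proto-oncogene Wnt-3 (Homo sapiens), read by a luciferase reporter, with a stated time of 18 h (a higher number here means that more compound is needed for the effect, a lower number that less compound is needed), compound 2 gives 30 nM, the lowest of the two numbers recorded; its nearest neighbour is compound 1 `CC(C)(C)OC(=O)N1CCC[C@H]1C(=O)N1CCC(NS(=O)(=O)c2cc(S(=O)(=O)c3ccccc3)ccc2C(F)(F)F)CC1`, which in this assay gives 60 nM, and the step of a 2.0-fold lower number from compound 1 to compound 2 (0.30 log units; within the scatter) lies within the scatter. Compound 3 `CN(C)C(=O)N1CCC[C@H]1C(=O)N1CCC(NS(=O)(=O)c2cc(S(=O)(=O)c3ccccc3)ccc2C(F)(F)F)CC1` differs from compound 2 by dimethylamino in place of (tert-butyl)amino on a carbonyl carbon. For the measured compounds named here, the only measured step that touches this same carbonyl carbon, tert-butoxy giving way to (tert-butyl)amino, was a 2.0-fold lower number from compound 1 to compound 2 (0.30 log units; within the scatter), so the numbers so far show no movement beyond the scatter at this position. On that basis a step of a 1.5-fold higher number from compound 2 to compound 3 (0.18 log units; within the scatter) is expected, that is, nothing that clearly exceeds the scatter, with a slight lean towards a higher number. The estimate for compound 3 in this assay is 45 nM, with a range from 15 nM to 150 nM.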

Compound 3, half-maximal effective concentration: 160 nM
For compound 3 the middle estimate is 3.6-fold (0.55 log units) below the measured one; measured number outside the range, above it.
By their numbers in this assay, from the lowest: compounds 2 and 1 (each within the scatter of the next); then compound 3.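

In this assay, the substituent on this carbonyl carbon now proves to matter: dimethylamino gives a 5.3-fold higher number from compound 2 to compound 3 (0.73 log units; beyond the scatter) and a 2.7-fold higher number from compound 1 to compound 3 (0.43 log units; beyond the scatter), both beyond the scatter, whereas the earlier step at this carbon stayed within it. The two groups carrying a tert-butyl remain within the scatter of each other, and only dimethylamino stands apart from them. Nothing available explains this shift.

The step from (tert-butyl)amino to dimethylamino removes the hydrogen-bond donor and also changes the heavy-atom count, and these compounds cannot separate the two changes. On these data alone, whether the higher number follows the loss of the amide hydrogen or the smaller group stays open, and a methylamino or isopropylamino group on the same carbonyl carbon would bear on that question.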